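Replacing a Carboxymethyl with a 4-Methoxyphenyl on Sulfur

This account rests on a few compounds, and the source may have more. Where it says the series, first, only, none or still open, it means among the compounds named here.

Compound 1, `CC(C(=O)NCc1ccc(C(F)(F)F)nc1SCCOc1ccccc1)c1ccc(NS(C)(=O)=O)c(F)c1`, 2.3 nM
Compound 2, `CC(C(=O)NCc1ccc(C(F)(F)F)nc1SCCC(=O)O)c1ccc(NS(C)(=O)=O)c(F)c1`, "not active" (no number reported)
Compound 3, `CC1CCC(Sc2nc(C(F)(F)F)ccc2CNC(=O)C(C)c2ccc(NS(C)(=O)=O)c(F)c2)CC1`, 0.5 nM

Of the compounds shown here, three have been tested in an assay on CHO-K1 cells for antagonist activity at transient receptor potential cation channel subfamily V member 1 (Homo sapiens), read by FLIPR; a lower number here means a stronger inhibitor, a higher number a weaker inhibitor. Compound 2 is reported as "not active" (no number reported), so no number places it on the scale; it stands apart from compound 1 and compound 3, which both give numbers. Compound 4, `COc1ccc(CSc2nc(C(F)(F)F)ccc2CNC(=O)C(C)c2ccc(NS(C)(=O)=O)c(F)c2)cc1`, differs from compound 2 in one place: 4-methoxyphenyl in place of carboxymethyl on a saturated chain carbon bound to a sulfur.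

Among the compounds with values here, no measured step matches this change directly. Within the data shown here, the one step available, a 4.6-fold lower number from compound 1 to compound 3 (0.66 log units; beyond the scatter), shows that among substituents on the sulfur a saturated ring and an aryl-containing chain both give low numbers in this assay, while the carboxymethyl chain of compound 2 gives none. Compound 4 carries an aromatic group on the sulfur, as compound 1 does, so the expectation is that compound 4 returns to the range seen for compound 1 and compound 3 rather than staying without a number.

Compound 4 is therefore estimated at 3 nM, with a range of 0.8 nM to 15 nM.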

Compound 4, inhibition constant: 2.3 nM
Estimate against measurement, compound 4: 1.3-fold (0.12 log units) above, within the range that was stated.
By their numbers in this assay, from the lowest: compound 3; then compounds 1 and 4 (each within the scatter of the next).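

In this assay compound 2, with its 2-carboxyethyl group on the sulfur, gave no number, whereas compound 4, with 4-methoxybenzyl there, gave 2.3 nM. The aromatic ring need not sit at the end of a longer chain, since the exchange of phenoxymethyl for 4-methoxyphenyl on the saturated chain carbon bound to the sulfur gave no change at the digits printed from compound 1 to compound 4 (within the scatter). The 4-methylcyclohexyl group still gave the lowest number of the series, with a 4.6-fold higher number from compound 3 to compound 4 (0.66 log units; beyond the scatter). Nothing given here accounts for these differences.

Going by these compounds, it remains open whether an amine or a methyl ester at the end of the chain would restore a number where the carboxylic acid of compound 2 gave none. On these data alone, it is also open whether a plain benzyl group would read like 4-methoxybenzyl.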